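A few compounds are considered here, and "the series" means these few. Any claim that something is new, unique, unknown or untested is made for them only; others in the source may bear on it.

Compound 1, `C#Cc1cn([C@@H]2O[C@H](CO)[C@@H](O)[C@H]2O)c2ncnc(N(C)C)c12`: in an ADME assay on MRC5 cells (Homo sapiens), read by MTT assay, with a stated time of 72 h (on this read-out higher numbers stand for weaker inhibition and lower numbers for stronger inhibition), compound 1 gives 36100 nM.
Compound 2, `O=c1[nH]cnc2c1c(-c1cccs1)cn2[C@@H]1O[C@H](CO)[C@@H](O)[C@H]1O`: in this assay compound 2 gives only a limit, > 100000 nM.

Compound 2 thus stands at the limit of > 100000 nM in this assay, at which 1 of the 2 values shown sits; only a limit, not a number, is known for it. Compound 3, `O=c1[nH]cnc2c1c(-c1ccco1)cn2[C@@H]1O[C@H](CO)[C@@H](O)[C@H]1O`, differs from compound 2 by furan-2-yl in place of thiophen-2-yl on an aromatic carbon. Within the data shown here, no measured pair in these data shows a comparable change, so nothing here points to a shift in either direction. The step that the limit leaves unreadable from compound 2 to compound 3 is expected to be none beyond the usual scatter. Compound 3 is therefore estimated at 120000 nM, within 40000 nM to 300000 nM, and may well again read only as a limit.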

Compound 3, half-maximal inhibitory concentration: > 100000 nM
Compound 3: a limit, no number; the forecaster's own chance of this, stated with the estimate: 70%; the middle value is on the limit's open side.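

Among these compounds, compound 2 and compound 3 both read only as limits, not numbers, and no step between them can be read. As far as these compounds go, what stays open is whether furan-2-yl and thiophen-2-yl differ at all on this read-out.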